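Amide-side variation within a shared-core inhibitor series

The compounds below may be only part of what the source reports. "The series", "measured", "known", "first", "only" and "open" are said of these compounds alone.

Measured so far, in a functional assay on HUVEC cells (Homo sapiens) for inhibition; a lower number here means a stronger inhibitor, a higher number a weaker inhibitor:
compound 1 `COc1cc(/C=C/C(=O)c2cccc(NC(=O)c3ccco3)c2)ccc1O` gives 0.38 ug/mL
compound 2 `COc1cc(/C=C/C(=O)c2cccc(NC(=O)C(C)C)c2)ccc1O` gives 1.44 ug/mL
compound 3 `COC(=O)C(=O)Nc1cccc(C(=O)/C=C/c2ccc(O)c(OC)c2)c1` gives 1.5 ug/mL

Compound 3 holds the highest of the three numbers. Its gap to compound 2 is within the scatter, so the two cannot be ordered; its gap to compound 1 is beyond the scatter, shown as a 3.9-fold higher number from compound 1 to compound 3 (0.60 log units; beyond the scatter), the change there being methoxycarbonyl in place of furan-2-yl on a carbonyl carbon.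

Compound 4 `COc1cc(/C=C/C(=O)c2cccc(NC(=O)c3cccs3)c2)ccc1O` has not been measured. Relative to compound 3 it differs as follows: thiophen-2-yl in place of methoxycarbonyl on a carbonyl carbon

The step that bears most directly on this is a 3.9-fold higher number from compound 1 to compound 3 (0.60 log units; beyond the scatter), where a five-membered aromatic ring with one hetero atom at the same carbonyl carbon gave the lower number. Thiophen-2-yl is likewise a five-membered aromatic ring with one hetero atom, so the reverse direction is expected here: a drop in this assay of roughly the size seen between compound 1 and compound 3. The step of a 3.8-fold higher number from compound 1 to compound 2 (0.58 log units; beyond the scatter) points the same way, with isopropyl rather than an aromatic ring giving the higher number. For the measured compounds named here, no thiophene-bearing compound has been measured, so the size is uncertain.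

For compound 4 the expected value in this assay is 0.45 ug/mL, within a range of 0.2 ug/mL to 1 ug/mL, an estimated step of a 3.3-fold lower number from compound 3 to compound 4 (0.52 log units; beyond the scatter).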

Compound 4, half-maximal inhibitory concentration: 0.38 ug/mL
Compound 4: the middle estimate sits 1.2-fold (0.07 log units) above what was measured, and the stated range covers the measured number.
By their numbers in this assay, from the lowest: compounds 1 and 4 (each within the scatter of the next); then compounds 2 and 3 (each within the scatter of the next).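

Working notes on the amide side: in this assay, exchanging the ring oxygen of furan-2-yl for the sulfur of thiophen-2-yl on the carbonyl carbon gives no change at the digits printed from compound 1 to compound 4 (within the scatter), so at this position the two rings cannot be told apart. The low number is therefore not peculiar to furan-2-yl: the thiophen-2-yl compound also separates from the two compounds without a ring at this carbon, with a 3.9-fold lower number from compound 3 to compound 4 (0.60 log units; beyond the scatter) against methoxycarbonyl and a 3.8-fold lower number from compound 2 to compound 4 (0.58 log units; beyond the scatter) against isopropyl, and none of the four compounds goes against this split. The data on hand offer no explanation for either the split or the match between the two rings.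

From the compounds shown here alone, it remains open whether the low number needs an aromatic ring at all, which a saturated ring such as tetrahydrofuran-2-yl or cyclopentyl would test, or a five-membered one, which phenyl or pyridin-2-yl would test. Also open, going by these compounds, are the effects of moving the ring attachment, as in thiophen-3-yl, and of adding a second ring hetero atom, as in thiazol-2-yl.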